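Sulfonyl aryl swap on a benzamide sulfonamide series

The source may report more compounds than this note shows. Statements on the series, on what has been measured and on what is new or still open speak of the compounds shown alone.

Measured compounds:
- Compound 1, `O=C(NCc1ccc(CNS(=O)(=O)c2ccc([N+](=O)[O-])cc2)cc1)c1cccnc1`: 100 nM
- Compound 2, `COc1ccccc1C(=O)NCc1ccc(CNS(=O)(=O)c2cccc(Cl)c2)cc1`: 1000 nM
- Compound 3, `Cc1ccccc1C(=O)NCc1ccc(CNS(=O)(=O)c2ccccc2Cl)cc1`: 1000 nM

Three compounds share the same core, and each has been measured in an assay on MDA-MB-231 cells for displacement of a labelled ligand from C-X-C chemokine receptor type 4 (Homo sapiens), read by fluorescence and microscopy, with stated times of 10 min and 30 min; on this read-out lower numbers stand for an effect already at smaller amounts and higher numbers for an effect only at larger amounts of compound. Compound 1 gives 100 nM, the lowest of the three numbers. Compound 2 gives 1000 nM, level with compound 3 at the digits shown, so the two cannot be ordered within the scatter; together they sit at the high end of the set, and compound 1 lies a clear step below them, beyond the scatter.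

The step under consideration starts from compound 2 and goes to compound 4, `COc1ccccc1C(=O)NCc1ccc(CNS(=O)(=O)c2ccccc2C)cc1`, not yet measured. The change is confined to the sulfonyl side of the molecule: 2-methylphenyl in place of 3-chlorophenyl on a sulfonyl sulfur. Within the data shown here, no measured pair in this set isolates the same difference, so nothing here reports how swapping 3-chlorophenyl for 2-methylphenyl on the sulfonyl sulfur moves the read-out.

Because compound 2 gives 1000 nM and compound 3 gives 1000 nM with different substituted phenyl groups on the sulfonyl sulfur, the expected step in this assay is none beyond the scatter, no change at the digits printed from compound 2 to compound 4 (within the scatter). Compound 4 is accordingly estimated at 1000 nM, within a range from 400 nM to 3000 nM.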

Compound 4, effective concentration (reported as EC, without a stated level of effect): 1000 nM
The estimate for compound 4 equals the measured number at the digits printed; measured number inside the range.
By their numbers in this assay, from the lowest: compound 1; then compounds 2, 3 and 4 (each within the scatter of the next).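

In this assay, the change now has its first measured pair with the rest of the molecule held the same: 2-methylphenyl in place of 3-chlorophenyl on a sulfonyl sulfur gives no change at the digits printed from compound 2 to compound 4 (within the scatter) and so leaves the read-out where it stood. The swap replaces a chlorine-bearing ring with an all-carbon one while keeping the heavy-atom count and the single six-membered aromatic ring, and for this one pair that exchange does not register in the number. Nothing in the data shown explains why this step is flat.

Among these compounds, one pair reads only one swap, so it remains open how this position responds to a phenyl ring carrying an amine or a carboxylic acid, or to a longer chain on the sulfonyl sulfur in place of the ring. Among the compounds shown here, compound 1, at 100 nM, is joined to the other compounds by no single-place step, so its value cannot be assigned to either its sulfonyl side or its amide side.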